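The source may report more compounds than this note shows. Statements on the series, on what has been measured and on what is new or still open speak of the compounds shown alone.

Measured so far:
compound 1 `COc1cc(-c2cc(/C=C/C(=O)c3ccc(Cl)c(Cl)c3)[nH]n2)cc(OC)c1OC`: 99%
compound 2 `COc1ccc(C(=O)/C=C/c2cc(-c3cc(OC)c(OC)c(OC)c3)n[nH]2)cc1OC`: 88%

For the measured compounds named here, in a functional assay on OVCAR-5 cells (Homo sapiens) for cytotoxicity, read by sulforhodamine B assay, with a stated time of 48 h, tested at 0.1 uM (on this read-out higher numbers stand for a weaker effect at the one concentration tested and lower numbers for a stronger effect), compound 2 stands lowest of the two numbers, the only step being a number 11 percentage points lower from compound 1 to compound 2 (beyond the scatter). Compound 3 `COc1ccc(C(=O)/C=C/c2cc(-c3cc(OC)c(OC)c(OC)c3)n[nH]2)cc1` differs from compound 2 by hydrogen in place of methoxy on an aromatic carbon. Going by the values given here, no measured step bears directly on removing a methoxy; the one step known concerns the whole aryl group on the carbonyl carbon and was modest. The step of a number 5 percentage points higher from compound 2 to compound 3 (within the scatter) is therefore expected to stay within the scatter, leaning toward a higher number. Compound 3 is estimated at 93%, within 82% to 101%.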

Compound 3, a percentage reported as activity, at one concentration (the size of the read-out at that concentration, not a potency): 97%
Compound 3: the middle estimate sits 4 percentage points below what was measured, and the stated range covers the measured number.
By their numbers in this assay, from the lowest: compounds 2, 3 and 1 (each within the scatter of the next, the first and the last beyond it).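

Removing the methoxy ortho to a methoxy group, 3,4-dimethoxyphenyl to 4-methoxyphenyl, gives a number 9 percentage points higher from compound 2 to compound 3 (within the scatter) in this assay and so shows no effect at this position that stands clear of the scatter. With 4-methoxyphenyl in place of 3,4-dichlorophenyl, the series gives a number 2 percentage points lower from compound 1 to compound 3 (within the scatter) and so the aryl change also stays inside the scatter when this methoxy is absent. Nothing at hand accounts for either step.

From the compounds shown here alone, whether an amine, a hydroxyl or a longer ether chain on this aromatic carbon would separate from compound 2 remains open.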